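Bromo in place of hydrogen on the shared core

This account rests on a few compounds, and the source may have more. Where it says the series, first, only, none or still open, it means among the compounds named here.

The two measured compounds share one core. Compound 1 `Cc1cccc2c1CC/C2=C\C(N)=O` carries a methyl on an aromatic carbon; in a functional assay on the whole organism with Mus musculus as the target (a higher number here means that more compound is needed for the effect, a lower number that less compound is needed), compound 1 gives > 100 mg/kg, which is a limit of the assay and not a number. Compound 2 `NC(=O)/C=C1\CCc2ccccc21` lacks that methyl. In this assay, among the compounds with values here, compound 2 gives 108 mg/kg, the only number among the two values. The other value, that of compound 1, is a limit (the limit of > 100 mg/kg in this assay, at which 1 of the 2 values shown sits). The step that the limit leaves unreadable from compound 1 to compound 2 therefore cannot be read in size.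

Compound 3 `NC(=O)/C=C1\CCc2ccc(Br)cc21` differs from compound 2 in one place: bromo in place of hydrogen on an aromatic carbon. Within the data shown here, the only measured step, from compound 1 to compound 2, is unreadable, so no step of the same kind gives a measured size for this change. The expectation for compound 3 in this assay thus rests on compound 2 alone, with a step of a 1.2-fold lower number from compound 2 to compound 3 (0.08 log units; within the scatter) that is expected to stay close to no change, and with a real chance that the assay returns only a limit. Compound 3 is estimated at 90 mg/kg, with a range from 30 mg/kg to 250 mg/kg.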

Compound 3, dose for half-maximal effect: 96 mg/kg
Estimate against measurement, compound 3: 1.1-fold (0.03 log units) below; low and high end bracket the measured number.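

In this assay, within the data shown here, putting bromo in place of hydrogen on this aromatic carbon, meta to a fused ring and para to a fused ring, gives a 1.1-fold lower number from compound 2 to compound 3 (0.05 log units; within the scatter), the first step on the shared core that can be read in size. The step is within the scatter, so this assay does not separate the two compounds, and this position carries a bromo, a single heavy atom with no ring, no hydrogen-bond donors or acceptors and no net charge, without a step beyond the scatter. Compound 1 remains at > 100 mg/kg, a limit of the assay and not a number, and its step to compound 2 cannot be read: the limit of > 100 mg/kg in this assay, at which 1 of the 3 values shown sits.

As far as these compounds go, one group at one position cannot speak for others, so it stays open whether an amine, a carboxylic acid or a longer chain on this aromatic carbon would also stay within the scatter of compound 2. From the compounds shown here alone, it is equally open how bromo would read on the other aromatic carbons of the shared core, including the one that carries the methyl in compound 1.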